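Aryl ester variation in a chromone series: bromo reintroduced

The source may hold more compounds than are shown below. What is called first, only, known or untested is meant among the compounds shown, and "the series" means these compounds.

Measured so far in a functional assay on cells (T-cell, Mus musculus, strain BALB/c) for inhibition, read by MTT assay, with a stated time of 72 h; a higher number here means a weaker inhibitor, a lower number a stronger inhibitor:
compound 1 `COC(=O)c1cc(Br)ccc1OC(=O)COc1cc(O)c2c(=O)cc(-c3ccccc3)oc2c1` — 780 nM
compound 2 `COC(=O)c1cc(C)ccc1OC(=O)COc1cc(O)c2c(=O)cc(-c3ccccc3)oc2c1` — 25700 nM

Compound 2 gives the highest number of the two compounds measured in this assay; its nearest neighbour is compound 1, and the step of a 33-fold higher number from compound 1 to compound 2 (1.52 log units; beyond the scatter) is large and well beyond the scatter. Compound 3 `COC(=O)c1ccc(Br)cc1OC(=O)COc1cc(O)c2c(=O)cc(-c3ccccc3)oc2c1` has not yet been measured. Relative to compound 2 the change is a group of 11 heavy atoms (8 carbon, 2 oxygen, 1 bromine; one six-membered aromatic ring of carbon only) in place of a group of 11 heavy atoms (9 carbon, 2 oxygen; one six-membered aromatic ring of carbon only), on an oxygen next to a carbonyl group. Compound 3 is therefore an isomer of compound 1, carrying bromine again on the ester-bound aromatic ring, but differently arranged on that ring.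

Going by the values given here, the only step that bears on this is a 33-fold higher number from compound 1 to compound 2 (1.52 log units; beyond the scatter), which shows how much the number rose when bromo was exchanged for methyl. Returning to bromo in compound 3 is expected to reverse much of that rise, but since compound 3 is not the same isomer as compound 1, the full return to the value of compound 1 is uncertain. A sizeable fall in the number is expected, a 10-fold lower number from compound 2 to compound 3 (1.01 log units; beyond the scatter), with a wide range. Compound 3 is estimated at 2500 nM, between 600 nM and 12000 nM.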

Compound 3, half-maximal inhibitory concentration: 17600 nM
Estimate against measurement, compound 3: 7.0-fold (0.85 log units) below, and the stated range ends below it.
By their numbers in this assay, from the lowest: compound 1; then compounds 3 and 2 (each within the scatter of the next).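

In this assay, bromine on the ester-bound aromatic ring does not by itself carry the low number of compound 1: the two bromo-bearing groups have the same heavy atoms, yet a 23-fold higher number from compound 1 to compound 3 (1.35 log units; beyond the scatter) is a large step, so at this oxygen next to a carbonyl group the arrangement on the ring counts as much as the identity of the substituent in this pair. The exchange of groups that separates the other pair gives a 1.5-fold lower number from compound 2 to compound 3 (0.16 log units; within the scatter), so compound 3 and compound 2 cannot be told apart here, and the bromo and methyl pair of compound 1 and compound 2 does not serve as a general guide to bromo against methyl on this ring. No measurement at hand explains why the arrangement matters in this way.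

Still open, going by these compounds, is whether a chloro or nitrile group in the arrangement of compound 1 would stay close to compound 1, which would separate the part played by bromine itself from the part played by its place on the ring. Also open, on these data alone, is how far the methyl ester on that ring matters, for instance whether a carboxylic acid or a primary amide in its place would keep the number of compound 1.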